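Removing one chlorine from a dichlorophenyl sulfone

The source may hold more compounds than are shown below. What is called first, only, known or untested is meant among the compounds shown, and "the series" means these compounds.

Compound 1 `COc1ccc(S(=O)(=O)c2cnc3ccc(OC)cc3c2N2CCC(C)CC2)cc1` and compound 2 `COc1ccc2ncc(S(=O)(=O)c3ccc(Cl)c(Cl)c3)c(N3CCC(C)CC3)c2c1` share a core and differ only in the ring on the sulfonyl sulfur. In an assay on isolated protein for displacement of a labelled ligand from metabotropic glutamate receptor 5 (Homo sapiens), with a stated time of 60 min, tested at 1 uM (a higher number here means more inhibition at the concentration tested (going by the name of the read-out), a lower number less inhibition), compound 1 gives 41%, while compound 2 gives 87%. That single change, 3,4-dichlorophenyl in place of 4-methoxyphenyl, produced a number 46 percentage points higher from compound 1 to compound 2 (beyond the scatter), so compound 2 stands highest of the two numbers, with compound 1 well below it.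

Compound 3 `COc1ccc2ncc(S(=O)(=O)c3cccc(Cl)c3)c(N3CCC(C)CC3)c2c1` is the next step: hydrogen in place of chloro on an aromatic carbon. For the measured compounds named here, no measured pair shows exactly this change; the only step known, the one from compound 1 to compound 2, swapped the whole ring rather than removing one chloro, so it bears on compound 3 only indirectly. Taking away part of what made compound 2 stand out is expected to cost some inhibition, but not all of it, giving an estimated step of a number 22 percentage points lower from compound 2 to compound 3 (beyond the scatter). Compound 3 is therefore expected to reach about 65%, most likely between 40% and 85%.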

Compound 3, a percentage reported as inhibition, at one concentration (the size of the read-out at that concentration, not a potency): -3%
The estimate for compound 3 lay 68 percentage points above the measured number; the measured number lies below the stated range.
By their numbers in this assay, from the lowest: compound 3; then compound 1; then compound 2.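

In this assay the chloro para to a large group accounts for nearly all of the inhibition seen with the 3,4-dichlorophenyl ring: replacing it with hydrogen, while the other chloro stays, gives a number 90 percentage points lower from compound 2 to compound 3 (beyond the scatter) and shows that the two chloro groups do not contribute equally. The 3-chlorophenyl ring is also no halfway point, for with it in place of 4-methoxyphenyl the result is a number 44 percentage points lower from compound 1 to compound 3 (beyond the scatter) and the ring with one chloro falls below both of the others. Nothing available explains this drop.

On these data alone, it remains open whether that place needs chloro itself or would also accept fluoro, methyl or trifluoromethyl. Also open, as far as these compounds go, is what 4-chlorophenyl, which keeps this chloro and loses the other, would give.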